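A few compounds are considered here, and "the series" means these few. Any claim that something is new, unique, unknown or untested is made for them only; others in the source may bear on it.

Compound 3 `C=C1CC[C@H]2[C@@](C)(CC[C@@H](OC(=O)c3ccccc3)[C@@]2(C)NC=O)[C@@H]1/C=C/C1=CCOC1=O` has so far given no number in an assay for inhibition of hexokinase-2 (Homo sapiens), read by coupled enzyme assay, with a stated time of 10 min, in the presence of a further agent that is not named here; a higher number here means a weaker inhibitor, a lower number a stronger inhibitor; its value in this assay, > 50000 nM, is a limit of the assay rather than a measurement. Compound 1 `C=C1CC[C@H]2[C@@](C)(CCC(=O)N[C@@]2(C)COC(=O)c2ccc([N+](=O)[O-])cc2)[C@@H]1/C=C/C1=CCOC1=O` likewise gives a limit in this assay of > 50000 nM. Compound 2 `C=C1CC[C@H]2[C@@](C)(CCC(=O)N[C@@]2(C)COC(=O)[C@@H]2CCCN2)[C@@H]1/C=C/C1=CCOC1=O` also gives a limit in this assay of > 50000 nM. The step that the two limits leave unreadable from compound 1 to compound 2, pyrrolidin-2-yl in place of 4-nitrophenyl on a carbonyl carbon, thus has no readable size, and all three values shown rest at the limit of > 50000 nM in this assay, at which 3 of the 3 values shown sit.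

Compound 4 `C=C1CC[C@H]2[C@@](C)(CC[C@@H](OC(=O)CCCC[C@@H]3CCSS3)[C@@]2(C)NC=O)[C@@H]1/C=C/C1=CCOC1=O` differs from compound 3 by a group of 9 heavy atoms (7 carbon, 2 sulfur; one five-membered non-aromatic ring with 2 hetero atoms) in place of a group of 6 heavy atoms (6 carbon; one six-membered aromatic ring of carbon only), on a carbonyl carbon. Going by the values given here, no measured step involves such an exchange, and the one step available gives no size at all. Among the compounds with values here, with every compound so far at the limit, compound 4 is expected to give about 50000 nM, within a range from 15000 nM to 200000 nM, most likely again as a limit. The expected step of a number no higher from compound 3 to compound 4 (the limit leaves the size open) is accordingly estimated as no change beyond the scatter.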

Compound 4, half-maximal inhibitory concentration: > 50000 nM
Compound 4: no number, only a limit; the forecaster's own chance of this, stated with the estimate: 75%; the middle value lies on the limit itself.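

In this assay compound 4 gives > 50000 nM, which is a limit and not a number. The step between compound 3 and compound 4 has no readable size, and no compound shown stands apart: the limit of > 50000 nM in this assay, at which 4 of the 4 values shown sit. The compounds shown leave open how strongly any of them inhibits the enzyme, and whether any exchanged group matters for that.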